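From Pyridin-3-yl to 2,5-Dichlorophenyl on the Ring Amine

The compounds below may be only part of what the source reports. "The series", "measured", "known", "first", "only" and "open" are said of these compounds alone.

Going by the values given here, in an assay on CHO cells for displacement of a labelled ligand from adenosine receptor A1 (Homo sapiens), read by scintillation counting, with a stated time of 120 min, tested at 10 uM (on this read-out lower numbers stand for less inhibition and higher numbers for more inhibition at the one concentration tested (going by the name of the read-out)), compound 1 `Nc1scc(CN2CCN(c3cccnc3)CC2)c1C(=O)c1ccc(Cl)cc1` gives 0%, the lowest of the two numbers measured so far. Compound 2 `Nc1scc(CN2CCN(c3cccc4ccccc34)CC2)c1C(=O)c1ccc(Cl)cc1` gives 1% in this assay, and the step of a number 1 percentage points higher from compound 1 to compound 2 (within the scatter) lies within the scatter of repeated measurements. Compound 3 `Nc1scc(CN2CCN(c3cc(Cl)ccc3Cl)CC2)c1C(=O)c1ccc(Cl)cc1` has not yet been measured. It differs from compound 1 by 2,5-dichlorophenyl in place of pyridin-3-yl on an amine nitrogen in a ring. Among the compounds with values here, the only measured step that bears on the same position is a number 1 percentage points higher from compound 1 to compound 2 (within the scatter), in which the same pyridin-3-yl gave way to naphthalen-1-yl; it produced no change beyond the scatter, and both measured numbers sit at the bottom of the read-out. The data therefore give no sign that exchanging the group on this ring nitrogen moves inhibition, so the step expected for a number 3 percentage points higher from compound 1 to compound 3 (within the scatter) is none beyond the scatter. Compound 3 is accordingly estimated to give 3%, within a range from 0% to 15%.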

Compound 3, a percentage reported as inhibition, at one concentration (the size of the read-out at that concentration, not a potency): 0%
Compound 3: middle estimate off by 3 percentage points, on the high side, within the range that was stated.
By their numbers in this assay, from the lowest: compounds 1, 3 and 2 (each within the scatter of the next).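

In this assay, putting 2,5-dichlorophenyl in place of pyridin-3-yl on the ring amine gives no change at the digits printed from compound 1 to compound 3 (within the scatter), and putting it in place of naphthalen-1-yl gives a number 1 percentage points lower from compound 2 to compound 3 (within the scatter). The position has now carried a third group, this one with two chlorine atoms and an aromatic ring of carbon only, and the read-out still shows no step beyond the scatter among compound 1, compound 2 and compound 3. Losing the ring nitrogen and hydrogen-bond acceptor of pyridin-3-yl therefore leaves the number at the bottom of the read-out, but nothing measured offers a reason for these low numbers.

The compounds shown leave open whether a benzyl group, a short alkyl chain or an acyl group on this ring nitrogen would give a number beyond the scatter. They also leave open whether these groups would read the same on a core changed elsewhere.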